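The source may hold more compounds than are shown below. What is called first, only, known or untested is meant among the compounds shown, and "the series" means these compounds.

Measured compounds:
Compound 1, `Cc1ccc(-c2ccnc(Nc3ccc4c(c3)c(/C=C3/C(=O)Nc5ccccc53)cn4C)n2)cc1`: in a functional assay on MCF7 cells (Homo sapiens) for cytotoxicity, read by MTT assay, with a stated time of 48 h (on this read-out lower numbers stand for stronger inhibition and higher numbers for weaker inhibition), compound 1 gives > 100000 nM, a limit of the assay rather than a number.
Compound 2, `COc1ccc(-c2ccnc(Nc3ccc4c(c3)c(/C=C3/C(=O)Nc5ccccc53)cn4C)n2)cc1`: in this assay compound 2 gives > 100000 nM, again a limit.
Compound 3, `Cn1cc(/C=C2/C(=O)Nc3ccccc32)c2cc(Nc3nccc(-c4ccc(O)cc4)n3)ccc21`: in this assay compound 3 gives 39600 nM.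

Compound 3 thus stands alone with a real number; the other two sit at the limit described by the limit of > 100000 nM in this assay, at which 2 of the 3 values shown sit. The step of an at least 2.5-fold lower number from compound 1 to compound 3 (0.40 log units; beyond the scatter) and the step of an at least 2.5-fold lower number from compound 2 to compound 3 (0.40 log units; beyond the scatter) both run toward the hydroxy compound and toward a lower number, while the step that the two limits leave unreadable from compound 1 to compound 2 cannot be read.

Compound 4, `Cn1cc(/C=C2/C(=O)Nc3ccccc32)c2cc(Nc3nccc(-c4ccc(F)cc4)n3)ccc21`, differs from compound 3 by fluoro in place of hydroxy on an aromatic carbon. The hydroxy group that set compound 3 apart from compound 1 and compound 2 leaves, so the two readable steps bear on this change in reverse. This step is therefore expected to be a 2.5-fold higher number from compound 3 to compound 4 (0.40 log units; beyond the scatter), quite possibly back to the limit. Compound 4 is estimated at 100000 nM, within a range of 30000 nM to 300000 nM.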

Compound 4, half-maximal inhibitory concentration: 48100 nM
Compound 4: middle estimate off by 2.1-fold (0.32 log units), on the high side; low and high end bracket the measured number.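

Swapping hydroxy for fluoro on this aromatic ring gives a 1.2-fold higher number from compound 3 to compound 4 (0.08 log units; within the scatter) in this assay, so compound 3 and compound 4 cannot be told apart, and a hydroxy group is not required here for a measurable number. The para group that gives a measurable number is therefore not hydroxy alone: fluoro in place of methoxy gives an at least 2.0-fold lower number from compound 2 to compound 4 (0.31 log units; beyond the scatter) and fluoro in place of methyl gives an at least 2.0-fold lower number from compound 1 to compound 4 (0.31 log units; beyond the scatter) as well. These two steps give only a minimum size, because compound 1 and compound 2 each sit at a limit rather than a number: the limit of > 100000 nM in this assay, at which 2 of the 4 values shown sit.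

As far as these compounds go, whether other groups in this place, such as an amine or a carboxylic acid, would stay at the level of compound 3 and compound 4 remains open. From the compounds shown here alone, how far compound 1 and compound 2 truly lie from that level also remains unknown.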